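Mirror image of a tetramethoxy diaryl butanol

This account rests on a few compounds, and the source may have more. Where it says the series, first, only, none or still open, it means among the compounds named here.

Compound 1 `COc1ccc(C(c2ccc(OC)c(OC)c2)[C@H](C)[C@H](C)CO)cc1OC`: in a functional assay on HL-60 cells (Homo sapiens) for cytotoxicity, read by WST assay, with a stated time of 48 h (a lower number here means a stronger inhibitor, a higher number a weaker inhibitor), compound 1 gives > 100000 nM, a limit of the assay.
Compound 2 `COc1cc(C(c2ccc(O)c(OC)c2)[C@H](CC(C)C)C(C)C)ccc1O`: in this assay compound 2 gives 9600 nM.
Compound 3 `COc1cc(C(c2ccc(O)c(OC)c2)[C@H](CO)C(C)C)ccc1O`: in this assay compound 3 gives > 100000 nM, a limit of the assay.

Compound 1 stands at the limit of this assay, and (the limit of > 100000 nM in this assay, at which 2 of the 3 values shown sit). Going by the values given here, the only measured step, an at least 10-fold higher number from compound 2 to compound 3 (1.01 log units; beyond the scatter), concerns a different change ( hydroxy in place of isopropyl ) and does not compare mirror images, so no step bears directly on an inversion of configuration.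

Compound 4 `COc1ccc(C(c2ccc(OC)c(OC)c2)[C@@H](C)[C@@H](C)CO)cc1OC` differs from compound 1 as follows: the two compounds have the same atoms and bonds and differ only in configuration as drawn: 2 of 2 stereo elements differ (all stereocentres are inverted: mirror images); a stereocentre at a saturated chain carbon is drawn S in compound 1 and R in compound 4; a stereocentre at a saturated chain carbon is drawn S in compound 1 and R in compound 4. Among the compounds with values here, with no measured mirror-image pair to lean on, the expected step is none beyond the scatter, a number no higher from compound 1 to compound 4 (the limit leaves the size open), most likely a limit again. The estimate for compound 4 in this assay is 100000 nM, within 30000 nM to 300000 nM.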

Compound 4, half-maximal inhibitory concentration: > 100000 nM
Compound 4: only a limit was reported (the forecaster's own chance of this, stated with the estimate: 85%); the middle value lies on the limit itself.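

Compound 1 and compound 4, mirror images of each other, both stand at a limit of this assay, so no step can be read between them. Going by these compounds, whether configuration changes the number for this pair remains open.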